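Swapping a cyanophenyl for a cyanocyclobutyl on a sulfonamide

This account rests on a few compounds, and the source may have more. Where it says the series, first, only, none or still open, it means among the compounds named here.

Compound 1 `NC(=O)[C@@H](CCC(F)(F)F)N(CC12CC(c3ncon3)(C1)C2)S(=O)(=O)c1ccc(Cl)cc1` gives 19.3 10^-6 cm/s in an ADME assay on MDCKII-LE cells (Canis lupus familiaris) for permeability (on this read-out lower numbers stand for lower permeability and higher numbers for higher permeability), and compound 2 `N#Cc1ccc(CN([C@H](CCC(F)(F)F)C(N)=O)S(=O)(=O)c2ccc(Cl)cc2)cc1` gives 19.7 10^-6 cm/s in this assay, the step being a 1.0-fold higher number from compound 1 to compound 2 (0.01 log units; within the scatter). Going by the values given here, compound 2 therefore sits alongside compound 1, the only other number, within the scatter. Compound 3 `N#C[C@H]1C[C@H](CN([C@H](CCC(F)(F)F)C(N)=O)S(=O)(=O)c2ccc(Cl)cc2)C1` carries 3-cyanocyclobutyl in place of 4-cyanophenyl on a saturated chain carbon bound to a sulfonamide nitrogen. Among the compounds with values here, the one step measured so far, a 1.0-fold higher number from compound 1 to compound 2 (0.01 log units; within the scatter), also replaced the group on that carbon and stayed within the scatter, so no step beyond the scatter is expected here, namely a 1.2-fold lower number from compound 2 to compound 3 (0.09 log units; within the scatter). Compound 3 is estimated at 16 10^-6 cm/s, ranging from 7 10^-6 cm/s to 32 10^-6 cm/s.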

Compound 3, apparent permeability: 24.9 10^-6 cm/s
Compound 3: middle estimate off by 1.6-fold (0.19 log units), on the low side, and the stated range covers the measured number.
By their numbers in this assay, from the lowest: compounds 1, 2 and 3 (each within the scatter of the next).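

In this assay, 3-cyanocyclobutyl in place of 4-cyanophenyl gave a step within the scatter (a 1.3-fold higher number from compound 2 to compound 3 (0.10 log units; within the scatter)), and so did the comparison with the larger group of compound 1 (a 1.3-fold higher number from compound 1 to compound 3 (0.11 log units; within the scatter)). This place, on a saturated chain carbon bound to a sulfonamide nitrogen, has now held an aromatic nitrile group and a non-aromatic one with no step beyond the scatter. Nothing available accounts for this result. On these data alone, whether an amine or a carboxylic acid at this place would give a step beyond the scatter remains open.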